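From 3-cyanophenyl to 2-fluorophenyl: notes on compound 3

A few compounds are considered here, and "the series" means these few. Any claim that something is new, unique, unknown or untested is made for them only; others in the source may bear on it.

Measured so far in a functional assay on HepG2 cells (Homo sapiens) for inhibition, read by MTT assay, with a stated time of 24 h; on this read-out lower numbers stand for stronger inhibition and higher numbers for weaker inhibition:
- compound 1 `CC1(C)[C@H]2CC[C@]1(C)N(Cc1cn(-c3ccc(C#N)cc3)nn1)C(=O)C2` gives 50 nM
- compound 2 `CC1(C)[C@H]2CC[C@]1(C)N(Cc1cn(-c3cccc(C#N)c3)nn1)C(=O)C2` gives 40 nM

For the measured compounds named here, compound 2 and compound 1, the only two measured compounds, lie within the scatter of each other. Compound 3 `CC1(C)[C@H]2CC[C@]1(C)N(Cc1cn(-c3ccccc3F)nn1)C(=O)C2` carries 2-fluorophenyl in place of 3-cyanophenyl on an aromatic nitrogen and keeps the shared core.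

Going by the values given here, the one measured step at this place is a 1.3-fold lower number from compound 1 to compound 2 (0.10 log units; within the scatter) and it stays within the scatter. Among the compounds with values here, that step only moves the nitrile, and no fluorophenyl compound has been measured, so it is weak guidance for the new group. The expected change in this assay is a 1.5-fold higher number from compound 2 to compound 3 (0.18 log units; within the scatter) and no firm move beyond the scatter is expected. The estimate for compound 3 is 60 nM and the expected range runs from 20 nM to 180 nM for this compound.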

Compound 3, half-maximal inhibitory concentration: 60 nM
Estimate against measurement, compound 3: no gap at the digits printed; the measured number falls inside the stated range.
By their numbers in this assay, from the lowest: compounds 2, 1 and 3 (each within the scatter of the next).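

In this assay, the change to 2-fluorophenyl gives a 1.5-fold higher number from compound 2 to compound 3 (0.18 log units; within the scatter) and, against the other nitrile compound, a 1.2-fold higher number from compound 1 to compound 3 (0.08 log units; within the scatter). The earlier step only moved the nitrile around the phenyl ring, whereas this change removes the nitrile with its triple bond and hydrogen-bond acceptor and brings in fluorine, yet compounds 1, 2 and 3 all remain within the scatter of one another, so among these three compounds the nitrile is not required for a value in this range. No supporting data bear on why these aryl groups read alike.

Going by these compounds, it remains open whether any group on this aromatic nitrogen can shift the number beyond the scatter, and whether the phenyl ring is needed at all. A phenyl ring bearing an amine or a carboxylic acid, or a simple butyl chain in place of the ring, would probe this.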